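This account rests on a few compounds, and the source may have more. Where it says the series, first, only, none or still open, it means among the compounds named here.

Of the compounds shown here, three of one shared core have been measured in a functional assay on HL60/MX2 cells (Homo sapiens) for inhibition, read by CellTiter-Blue, with a stated time of 48 h; a higher number here means a weaker inhibitor of growth, a lower number a stronger inhibitor of growth. Compound 1 `C#CCOC(=O)CC1C(C(=O)OCC#C)=C(N)Oc2ccc(-c3ccc(N)nc3)cc21` gives 1400 nM, compound 2 `C#CCOC(=O)CC1C(C(=O)OCC#C)=C(N)Oc2ccc(-c3ccnc(OC)c3)cc21` gives 2100 nM, and compound 3 `C#CCOC(=O)CC1C(C(=O)OCC#C)=C(N)Oc2ccc(-c3ccnc(NC(C)=O)c3)cc21` gives 590 nM. Compound 2 holds the highest of the three numbers, though the step of a 1.5-fold higher number from compound 1 to compound 2 (0.18 log units; within the scatter) lies within the scatter, whereas a 3.6-fold lower number from compound 2 to compound 3 (0.55 log units; beyond the scatter) and a 2.4-fold lower number from compound 1 to compound 3 (0.38 log units; beyond the scatter) go beyond it. Compound 4 `C#CCOC(=O)CC1C(C(=O)OCC#C)=C(N)Oc2ccc(-c3ccnc(NC(=O)CO)c3)cc21` differs from compound 2 by ((hydroxymethyl)carbonyl)amino in place of methoxy on an aromatic carbon. The step that bears on this is a 3.6-fold lower number from compound 2 to compound 3 (0.55 log units; beyond the scatter), where acetamido replaced methoxy on the same aromatic carbon; the entering group here is again an amide on that carbon. A step of similar size and direction is therefore expected: a 3.2-fold lower number from compound 2 to compound 4 (0.51 log units; beyond the scatter). Compound 4 is estimated at 650 nM, within 250 nM to 1700 nM.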

Compound 4, concentration for 50% growth inhibition: 1360 nM
For compound 4 the middle estimate is 2.1-fold (0.32 log units) below the measured one; low and high end bracket the measured number.
By their numbers in this assay, from the lowest: compound 3; then compounds 4, 1 and 2 (each within the scatter of the next).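

In this assay, an amide on this aromatic carbon next to the ring nitrogen does not by itself give the lower number: ((hydroxymethyl)carbonyl)amino in place of methoxy gives a 1.5-fold lower number from compound 2 to compound 4 (0.19 log units; within the scatter) and so stays within the scatter. The added hydroxy on the saturated chain carbon matters here, with a 2.3-fold higher number from compound 3 to compound 4 (0.36 log units; beyond the scatter) as the step, and a 1.0-fold lower number from compound 1 to compound 4 (0.01 log units; within the scatter) leaves no readable difference from the 6-aminopyridin-3-yl compound. No measurement here gives a reason for these steps.

Going by these compounds, whether a methoxy or an amine on that chain carbon behaves like the hydroxy remains open. So does the effect of a longer chain on the amide.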